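Replacing 2-methoxyphenyl with 3-chlorophenyl in compound 2

The source may report more compounds than this note shows. Statements on the series, on what has been measured and on what is new or still open speak of the compounds shown alone.

In a functional assay on HCT-116 cells (Homo sapiens) for antiproliferative activity, with a stated time of 72 h (on this read-out higher numbers stand for weaker inhibition and lower numbers for stronger inhibition), compound 2 `COc1ccccc1/C=C/c1nc(Nc2cccc(O)c2)c2ccccc2n1` gives 16400 nM as its measured value. Its nearest neighbour on these numbers, compound 1 `COc1ccccc1/C=C/c1nc(Nc2ccccc2Cl)c2ccccc2n1`, gives 16100 nM on the same read-out. For compound 3 `CCOc1ccc(/C=C/c2nc3ccccc3c(=O)[nH]2)cc1` a limit is all that this assay reports, namely > 25000 nM here.

Compound 4 `Oc1cccc(Nc2nc(/C=C/c3cccc(Cl)c3)nc3ccccc23)c1` differs from compound 2 by a single swap: 3-chlorophenyl in place of 2-methoxyphenyl on a double-bonded chain carbon bound to a double-bonded chain carbon with the rest unchanged. Among the measured compounds shown here, no measured step touches that place. For the measured compounds named here, the only step available, a 1.0-fold higher number from compound 1 to compound 2 (0.01 log units; within the scatter), concerns a different group, 3-hydroxyphenyl in place of 2-chlorophenyl, and so offers only a weak guide. With so little to go on, no shift beyond the scatter is expected in either direction, and the uncertainty stays wide. The estimated step is a 1.2-fold lower number from compound 2 to compound 4 (0.07 log units; within the scatter) and no more than that is expected. For compound 4 the estimate is 14000 nM (expected range 5000 nM to 25000 nM).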

Compound 4, half-maximal inhibitory concentration: > 25000 nM
Compound 4 was reported as a limit; the forecaster's own chance of this, stated with the estimate: 15%; middle value at least 1.7-fold (0.25 log units) away from the limit.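

Among the compounds shown here, at this place, on a double-bonded chain carbon bound to a double-bonded chain carbon, the earlier compounds offered no measured change; now, in this assay, 3-chlorophenyl in place of 2-methoxyphenyl gives an at least 1.5-fold higher number from compound 2 to compound 4 (0.18 log units; that floor lies within the scatter). From the compounds shown here alone, this swap therefore brings no visible gain in inhibition, but the step has only a floor, so its true size stays unknown and that floor alone does not establish a real loss. The reading for compound 4 is a limit and not a number: the limit of > 25000 nM in this assay, at which 2 of the 4 values shown sit.

The compounds shown leave open whether a measurable value could be recovered at this place with an amine or a carboxylic acid in place of 3-chlorophenyl. They also leave open how 3-chlorophenyl at this place would read with 2-chlorophenyl on the nitrogen instead of 3-hydroxyphenyl.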